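From compound 3 to compound 4: a step among limits

The compounds below may be only part of what the source reports. "The series", "measured", "known", "first", "only" and "open" are said of these compounds alone.

Values measured in an in vitro ADME assay on microsomes from liver (Homo sapiens) for metabolic stability, tested at 5 uM (a higher number here means that the compound lasts longer, a lower number that the compound disappears faster), follow, each one a limit and not a number.

- Compound 1 `CC(C)Cn1nc(-c2cccs2)c(O)c(C2=NS(=O)(=O)c3cc(NS(C)(=O)=O)ccc3N2)c1=O` gives > 1 h as a limit
- Compound 2 `CS(=O)(=O)Nc1ccc2c(c1)S(=O)(=O)N=C(c1c(O)c(-c3cccs3)nn(CCC3CCC3)c1=O)N2` gives > 1 h as a limit
- Compound 3 `CS(=O)(=O)Nc1ccc2c(c1)S(=O)(=O)N=C(c1c(O)c(-c3cccs3)nn(Cc3ccccn3)c1=O)N2` gives > 1 h as a limit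

Compound 3 thus stands at > 1 h in this assay as a limit, and no number is known for it. The same holds for the other two compounds (the limit of > 1 h in this assay, at which 3 of the 3 values shown sit) and they cannot be put in order.

The next structure is compound 4 `CS(=O)(=O)Nc1ccc2c(c1)S(=O)(=O)N=C(c1c(O)c(-c3cccs3)nn(Cc3ccc(F)cc3)c1=O)N2` with 4-fluorophenyl in place of pyridin-2-yl on a saturated chain carbon bound to an aromatic nitrogen as the whole change.

Two measured steps at this place bear on it, a step that the two limits leave unreadable from compound 1 to compound 3 and also a step that the two limits leave unreadable from compound 2 to compound 3 and neither has a readable size, so nothing beyond the usual scatter is expected, in either direction.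

The expected change is a step that the limit leaves unreadable from compound 3 to compound 4 in this assay for this swap.

Compound 4 is estimated at 1.3 h with an expected range from 0.6 h to 2.8 h and will probably be reported as a limit once more.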

Compound 4, half-life: > 1 h
Compound 4 ended at the assay's limit (the forecaster's own chance of this, stated with the estimate: 75%); the middle value does not contradict the limit.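

The step from compound 3 to compound 4 and those from compound 1 and compound 2 to compound 4 cannot be read, because all four compounds share one limit: the limit of > 1 h in this assay, at which 4 of the 4 values shown sit.

The compounds shown leave open the actual half-life of each compound and whether these side groups differ at all.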